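Para substituent swap on a bis-aminomethyl phenol chalcone

The compounds below may be only part of what the source reports. "The series", "measured", "known", "first", "only" and "open" are said of these compounds alone.

Two measured compounds share a common core and differ only on the distal aromatic ring. Compound 1 `CN(C)Cc1cc(C(=O)/C=C/c2ccc(Cl)cc2)cc(CN(C)C)c1O` carries a chloro group there, and in a functional assay on cells (Tumor Cell line, Homo sapiens) for cytotoxicity (on this read-out lower numbers stand for stronger inhibition and higher numbers for weaker inhibition), compound 1 gives 10000 nM. Compound 2 `CN(C)Cc1cc(C(=O)/C=C/c2ccc(F)cc2)cc(CN(C)C)c1O` carries a fluoro group instead, and in this assay compound 2 gives 20000 nM. Among the compounds with values here, on the two numbers available, compound 2 sits at the upper end, yet the only step recorded, a 2.0-fold higher number from compound 1 to compound 2 (0.30 log units; within the scatter), is within the scatter, so the two compounds cannot be told apart on this read-out.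

Compound 3 `CN(C)Cc1cc(C(=O)/C=C/c2ccc([N+](=O)[O-])cc2)cc(CN(C)C)c1O` is not yet measured. It differs from compound 2 as follows: nitro in place of fluoro on an aromatic carbon. Within the data shown here, the one measured step bears on this change only loosely, as it exchanged one halogen for another rather than introducing a nitro group, and it was within the scatter. With no larger shift seen at this position, compound 3 is expected to stay close to compound 2, a step of a 2.0-fold lower number from compound 2 to compound 3 (0.30 log units; within the scatter) in this assay. Compound 3 is therefore estimated at 10000 nM, with a range from 3000 nM to 40000 nM.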

Compound 3, half-maximal inhibitory concentration: 8910 nM
For compound 3 the middle estimate is 1.1-fold (0.05 log units) above the measured one; the range from low to high includes it.
By their numbers in this assay, from the lowest: compounds 3, 1 and 2 (each within the scatter of the next, the first and the last beyond it).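

Within the data shown here, exchanging the fluoro group for nitro gives the first step at this position that lies beyond the scatter in this assay: there is a 2.2-fold lower number from compound 2 to compound 3 (0.35 log units; beyond the scatter), although the shift is modest. Set against the chloro group, the nitro group gives a 1.1-fold lower number from compound 1 to compound 3 (0.05 log units; within the scatter) and the two compounds of that step cannot be told apart on this read-out. Nothing measured here accounts for the separation of the nitro compound from the fluoro compound, and no supporting data bear on it. The compounds shown leave open whether an amine, a carboxylic acid or a longer chain at this place, para to a large group, would move the number further than the nitro group does. They also leave open whether the 4-fluorophenyl to 4-nitrophenyl step would hold on a different core.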